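A few compounds are considered here, and "the series" means these few. Any claim that something is new, unique, unknown or untested is made for them only; others in the source may bear on it.

Working notes on the amide series around the shared core of compound 1.

Within the data shown here, compound 1 `COc1cc2c(Oc3ccc(NC(=O)c4cc(-c5ccccc5)nc5ccc(F)cc45)cc3F)ccnc2cc1OCCCN1CCCCC1` holds the lowest of the two numbers measured so far in a functional assay on NCI-H460 cells (Homo sapiens) for cytotoxicity, read by MTT assay, with a stated time of 72 h; a higher number here means a weaker inhibitor, a lower number a stronger inhibitor: compound 1 gives 32 nM. Among the measured compounds shown here, the only other measured member is compound 2 `COc1ccc(-c2cc(C(=O)Nc3ccc(Oc4ccnc5cc(OCCCN6CCCCC6)c(OC)cc45)c(F)c3)c3cc(F)ccc3n2)cc1`, which in this assay gives 240 nM. For the measured compounds named here, the one measured step, a 7.5-fold higher number from compound 1 to compound 2 (0.88 log units; beyond the scatter), is a methoxy in place of hydrogen on an aromatic carbon of the aryl group that hangs from the quinoline-side ring system, far from the amine-terminated chain.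

Compound 3 `COc1cc2c(Oc3ccc(NC(=O)c4cc(-c5ccccc5)nc5ccc(F)cc45)cc3F)ccnc2cc1OCCCN1CCCC1` is not yet measured. It differs from compound 1 only in the amine at the chain end: pyrrolidin-1-yl in place of piperidin-1-yl on a saturated chain carbon, three bonds along the chain from an oxygen on an aromatic ring. Going by the values given here, no measured step touches that chain end, and the single step in hand, a 7.5-fold higher number from compound 1 to compound 2 (0.88 log units; beyond the scatter), concerns a different part of the molecule, so it carries no information on this change. With nothing in the measured pairs bearing on the ring size of the terminal amine, compound 3 is expected to sit close to compound 1, with a step of a 1.3-fold higher number from compound 1 to compound 3 (0.10 log units; within the scatter) that stays within the scatter, and its value in this assay is estimated at 40 nM, within 15 nM to 120 nM.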

Compound 3, half-maximal inhibitory concentration: 90 nM
Estimate against measurement, compound 3: 2.3-fold (0.35 log units) below; the range from low to high includes it.
By their numbers in this assay, from the lowest: compound 1; then compound 3; then compound 2.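

The terminal amine is not a silent part of the molecule: in this assay, going from the six-membered to the five-membered non-aromatic ring gives a 2.8-fold higher number from compound 1 to compound 3 (0.45 log units; beyond the scatter), although the hydrogen-bond donor and acceptor counts and the net charge of the two groups are the same. The chain end thus joins the methoxy place on the aryl group as a second place where a single change from compound 1 moves the number beyond the scatter, and in both measured steps compound 1 keeps the lower number. Nothing at hand gives any measurement that would account for this step at the chain end.

Two ring sizes cannot show whether the number follows ring size in general, so a seven-membered azepan-1-yl end, a morpholin-4-yl end or an open-chain dimethylamino end would each be informative here. Also open, going by these compounds, are how a longer chain than the propyl linker would read, and whether the pyrrolidin-1-yl change gives a similar step when the methoxy of compound 2 is present on the aryl group.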